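Cytotoxic sulfonate nucleoside series: step from compound 2 to 3

This account rests on a few compounds, and the source may have more. Where it says the series, first, only, none or still open, it means among the compounds named here.

Measured so far:
compound 1 `CCOC(=O)NC(=O)NC1=CS(=O)(=O)O[C@@]12[C@@H](CO[Si](C)(C)C(C)(C)C)O[C@@H](n1cc(C)c(=O)n(C)c1=O)[C@@H]2O[Si](C)(C)C(C)(C)C`: 3000 nM
compound 2 `COC(=O)NC1=CS(=O)(=O)O[C@@]12[C@@H](CO[Si](C)(C)C(C)(C)C)O[C@@H](n1cc(C)c(=O)n(C)c1=O)[C@@H]2O[Si](C)(C)C(C)(C)C`: 30700 nM

In a functional assay on CCRF-CEM cells (Homo sapiens) (on this read-out lower numbers stand for higher toxicity in this test and higher numbers for lower toxicity in this test), compound 2 gives the highest of the two numbers; its nearest neighbour is compound 1 with 3000 nM, a step of a 10-fold higher number from compound 1 to compound 2 (1.01 log units; beyond the scatter). Compound 3 `Cc1cn([C@@H]2O[C@H](CO[Si](C)(C)C(C)(C)C)[C@@]3(OS(=O)(=O)C=C3NCCC(=O)OCc3ccccc3)[C@H]2O[Si](C)(C)C(C)(C)C)c(=O)n(C)c1=O` differs from compound 2 as 2-(benzyloxycarbonyl)ethyl in place of methoxycarbonyl on an amine nitrogen. Within the data shown here, the one measured step touches the same nitrogen substituent but swaps groups on the carbonyl carbon, not the whole group; it bears only loosely here. No direction is therefore firmly expected beyond the scatter, with a modest lowering allowed. Compound 3 is estimated at 20000 nM (range 5000 nM to 80000 nM), a step of a 1.5-fold lower number from compound 2 to compound 3 (0.19 log units; within the scatter).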

Compound 3, half-maximal cytotoxic concentration: > 250000 nM
Compound 3 ended at the assay's limit (the forecaster's own chance of this, stated with the estimate: 10%); at least 12-fold (1.09 log units) between middle value and limit.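

In this assay, the substituent on the amine nitrogen can move the read-out further than the carbonyl change seen earlier: 2-(benzyloxycarbonyl)ethyl in place of methoxycarbonyl gives an at least 8.1-fold higher number from compound 2 to compound 3 (0.91 log units; beyond the scatter), and in place of (ethoxycarbonyl)carbamoyl it gives an at least 83-fold higher number from compound 1 to compound 3 (1.92 log units; beyond the scatter). The value of compound 3 is a limit, not a number: the limit of > 250000 nM in this assay, at which 1 of the 3 values shown sits.

The change brings in the ethyl link and the benzyl ester together, and the compounds shown do not separate them. From the compounds shown here alone, how a carboxylic acid at the end of this chain, or an unsubstituted amine, would read remains open.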